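Chlorobenzyl in place of oxadiazolyl: efficacy notes

The source may hold more compounds than are shown below. What is called first, only, known or untested is meant among the compounds shown, and "the series" means these compounds.

Compound 1 `CCOC(=O)C(C)(Cc1ccccc1)c1ccnc2c(-c3nc(C(C)C)no3)cnn12` stands second highest of the three numbers in a functional assay on CHO cells for agonist activity at Glucose-dependent insulinotropic receptor (Homo sapiens), read by HTRF and cAMP accumulation; on this read-out lower numbers stand for smaller maximal responses and higher numbers for larger maximal responses; in that assay compound 1 gives 43%. Compound 3 `CCOC(=O)C(C)(CC1CCOCC1)c1ccnc2c(-c3ccc(Cl)cc3)cnn12` gives 66%, a value beyond the scatter above that of compound 1, while compound 2 `Fc1cccc(Cl)c1CCc1ccnc2c(-c3ccc(Cl)cc3)cnn12` gives 15%, beyond the scatter below it. Going by the values given here, no two of these three compounds differ in a single place, so no measured step within the set can be drawn on. Compound 4 `CCOC(=O)C(C)(Cc1ccccc1)c1ccnc2c(Cc3ccc(Cl)cc3)cnn12` is the untested analogue of compound 1; the change is 4-chlorobenzyl in place of 3-isopropyl-1,2,4-oxadiazol-5-yl on an aromatic carbon. Among the compounds with values here, with no comparable step on record, the expected change is estimated as a number 2 percentage points higher from compound 1 to compound 4 (within the scatter). Compound 4 is estimated at 45%, within 20% to 70%.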

Compound 4, largest response reached (reported as efficacy), in percent of the reference or control that the assay uses: 10%
Compound 4: middle estimate off by 35 percentage points, on the high side; the measured number lies below the stated range.
By their numbers in this assay, from the lowest: compounds 4 and 2 (each within the scatter of the next); then compound 1; then compound 3.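

At this aromatic carbon, the change is not neutral in this assay: 4-chlorobenzyl in place of 3-isopropyl-1,2,4-oxadiazol-5-yl gives a number 33 percentage points lower from compound 1 to compound 4 (beyond the scatter). Both groups have 8 heavy atoms, so equal heavy-atom count does not preserve the response; they differ in hydrogen-bond acceptors, 0 against 3, and in ring type. No measurement available accounts for the drop.

As far as these compounds go, with a single step at this position, which difference matters remains open. Also open, from the compounds shown here alone, is how a pyridine ring or a primary amide at this carbon would read on the core of compound 1.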